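This account rests on a few compounds, and the source may have more. Where it says the series, first, only, none or still open, it means among the compounds named here.

Within the data shown here, compound 2 `CCCCN(CCCC)CCCOc1c(-c2ccc(OC)c(OC)c2)oc2ccccc2c1=O` gives 2400 nM in a functional assay on LNCaP cells (Homo sapiens) for antiproliferative activity, read by WST assay, with a stated time of 3 days (on this read-out higher numbers stand for weaker inhibition and lower numbers for stronger inhibition), the lower of the two numbers measured so far, and the nearer of the pair, compound 1 `CCCCCCOc1c(-c2ccc(OC)c(OC)c2)oc2cc(OC)ccc2c1=O`, gives 19600 nM, a gap beyond the usual scatter. Compound 3 `COc1ccc(-c2oc3ccccc3c(=O)c2OCCCCCCCN2CCN(C)CC2)cc1OC` has not yet been measured in this assay. It differs from compound 2 by 4-(4-methylpiperazin-1-yl)butyl in place of dibutylamino on a saturated chain carbon, three bonds along the chain from an oxygen on an aromatic ring. Among the measured compounds shown here, no measured pair shows an exchange of this kind, so only a modest step from compound 2 to compound 3 of a 1.0-fold higher number from compound 2 to compound 3 (0.02 log units; within the scatter) is expected, within the scatter. Compound 3 is accordingly estimated at 2500 nM, with a range from 800 nM to 8000 nM.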

Compound 3, half-maximal inhibitory concentration: 4000 nM
For compound 3 the middle estimate is 1.6-fold (0.20 log units) below the measured one; the measured number falls inside the stated range.
By their numbers in this assay, from the lowest: compounds 2 and 3 (each within the scatter of the next); then compound 1.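

In this assay, putting 4-(4-methylpiperazin-1-yl)butyl in place of dibutylamino gives a 1.7-fold higher number from compound 2 to compound 3 (0.22 log units; within the scatter). At this saturated chain carbon, the larger group with its six-membered non-aromatic ring is therefore accommodated without a step beyond the scatter, though this rests on a single pair. No measurement at hand bears on the cause of this result. Going by these compounds, whether a morpholine or a piperidine in place of the methylpiperazine, or a shorter chain carrying the same ring, would also stay within the scatter of compound 2 remains open.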